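The source may report more compounds than this note shows. Statements on the series, on what has been measured and on what is new or still open speak of the compounds shown alone.

Three compounds that share one core and differ only in a single amino group have been measured in an ADME assay on A549 cells (Homo sapiens) for cytotoxicity, read by resazurin assay, with a stated time of 48 h; on this read-out higher numbers stand for lower toxicity in this test and lower numbers for higher toxicity in this test. Compound 1 `CCNc1ccc(NC(=O)c2cc(Cl)ccc2O)c(Cl)c1`, carrying ethylamino, gives 30200 nM. Compound 2 `O=C(Nc1ccc(NC2CCCCC2)cc1Cl)c1cc(Cl)ccc1O`, carrying cyclohexylamino, gives 68300 nM. Compound 3 `CCCN(CCC)c1ccc(NC(=O)c2cc(Cl)ccc2O)c(Cl)c1`, carrying dipropylamino, gives 10700 nM, the lowest of the three numbers.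

Compound 4 `O=C(Nc1ccc(N(CC2CC2)CC2CC2)cc1Cl)c1cc(Cl)ccc1O` has not been measured yet. Its change from compound 3 is bis(cyclopropylmethyl)amino in place of dipropylamino on an aromatic carbon.

Three measured steps involve this same position: a 2.3-fold higher number from compound 1 to compound 2 (0.35 log units; beyond the scatter), a 2.8-fold lower number from compound 1 to compound 3 (0.45 log units; beyond the scatter) and a 6.4-fold lower number from compound 2 to compound 3 (0.81 log units; beyond the scatter). All are modest, though beyond the scatter. They show that changing this group can move the number, but each one involves ethylamino or cyclohexylamino. Within the data shown here, no measured step replaces dipropylamino with a similar group, so the data give no direction for this change.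

In this assay, a modest step at most is expected, and quite possibly none beyond the scatter. The expected step is a 1.1-fold lower number from compound 3 to compound 4 (0.03 log units; within the scatter). The anchor for the expectation is compound 3 at 10700 nM. Compound 4 is estimated at 10000 nM, with an expected range from 4500 nM to 25000 nM.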

Compound 4, half-maximal cytotoxic concentration: 12800 nM
Compound 4: middle estimate off by 1.3-fold (0.11 log units), on the low side, and the stated range covers the measured number.
By their numbers in this assay, from the lowest: compounds 3 and 4 (each within the scatter of the next); then compound 1; then compound 2.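

In this assay, swapping the straight propyl chains for cyclopropylmethyl groups brings in two three-membered rings and yet gives only a 1.2-fold higher number from compound 3 to compound 4 (0.08 log units; within the scatter), so this test does not tell these two groups apart. The new group does stand apart from the two amino groups that carry a single carbon substituent on the nitrogen, with a 5.3-fold lower number from compound 2 to compound 4 (0.73 log units; beyond the scatter) and a 2.4-fold lower number from compound 1 to compound 4 (0.37 log units; beyond the scatter); among these four compounds, then, both disubstituted amino groups give lower numbers, meaning higher toxicity in this test, than both monosubstituted ones, and no compound here goes against that pattern. Nothing measured here explains this split between the disubstituted and monosubstituted groups.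

Still open, going by these compounds, is whether the pattern holds for a smaller group such as dimethylamino, for longer chains such as dibutylamino, or for a nitrogen tied back into a ring, as in piperidine or morpholine. A plain unsubstituted amine at this position would also show how far the number depends on having any carbon substituent on the nitrogen at all.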